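A few compounds are considered here, and "the series" means these few. Any claim that something is new, unique, unknown or untested is made for them only; others in the source may bear on it.

Of the compounds shown here, three have been measured in a functional assay on HCC827 cells (Homo sapiens) for inhibition, read by MTT assay, with a stated time of 48 h, tested at 10 uM (a higher number here means more inhibition at the concentration tested (going by the name of the read-out), a lower number less inhibition), and they share a urea-linked core with an aryl amine on one side. Compound 1 `COc1cc(NC(=O)Nc2cc(Nc3cccc(C(C)(C)C)c3)ncn2)cc(OC)c1` gives 48.7% in this assay, which places it second highest of the three numbers. For the measured compounds named here, its nearest neighbour is compound 3 `CC(C)(C)c1ccc(Nc2cc(NC(=O)Nc3c(Cl)cccc3Cl)ncn2)cc1`, which gives 42.3% in this assay, a result within the usual scatter of the one for compound 1, so no order between these two can be claimed. The furthest is compound 2 `COc1ccc(Nc2cc(NC(=O)Nc3c(Cl)cccc3Cl)ncn2)cc1C`, which gives 63.1% in this assay, a result that lies beyond the scatter above compound 1. Compound 2 differs from compound 1 in more than one place, so no single change can be tied to that gap.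

The compound still to be measured is compound 4 `COc1cc(NC(=O)Nc2cc(Nc3ccc(Br)cc3OC)ncn2)cc(OC)c1`. Compared with compound 1, the change is 4-bromo-2-methoxyphenyl in place of 3-(tert-butyl)phenyl on a nitrogen on an aromatic ring. No pair of measured compounds differs by this change alone, so the size of the step cannot be read from the numbers shown. The step from compound 1 to compound 4 is expected to be small, a number 3.3 percentage points higher from compound 1 to compound 4 (within the scatter), and not clearly beyond the scatter in either direction. Compound 4 is therefore estimated at 52% in this assay, with a likely range from 32% to 72%.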

Compound 4, a percentage reported as inhibition, at one concentration (the size of the read-out at that concentration, not a potency): 57.7%
Compound 4: the middle estimate sits 5.7 percentage points below what was measured, and the stated range covers the measured number.
By their numbers in this assay, from the lowest: compounds 3, 1, 4 and 2 (each within the scatter of the next, the first and the last beyond it).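

In this assay, putting 4-bromo-2-methoxyphenyl in place of 3-(tert-butyl)phenyl on a nitrogen on an aromatic ring gives a number 9 percentage points higher from compound 1 to compound 4 (within the scatter), so no order between the two compounds can be claimed. For the compounds shown here, this is the first single-place comparison, and it shows that this position can carry two quite different aromatic groups with no difference beyond the usual scatter: the 3-(tert-butyl)phenyl group is all carbon and has no hydrogen-bond acceptor, while the group that enters brings bromine, oxygen and one hydrogen-bond acceptor. Nothing measured here bears on why the two groups give such similar numbers.

From the compounds shown here alone, it remains open whether the same exchange would give a similar step with the dichlorophenyl group that compound 2 and compound 3 carry on the urea in place of the dimethoxyphenyl group of compound 1 and compound 4. Going by these compounds, it is also open how a very different group at this nitrogen, such as a phenyl ring bearing a carboxylic acid or a piperazine, would read at the one concentration used.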